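Boc removal on the furfuryl amide: second instance

The compounds below may be only part of what the source reports. "The series", "measured", "known", "first", "only" and "open" are said of these compounds alone.

Compound 1 `CC(C)(C)OC(=O)N(Cc1ccco1)C(=O)c1ccc(CN2Cc3ccccc3C2=O)cc1` and compound 2 `O=C(NCc1ccco1)c1ccc(CN2Cc3ccccc3C2=O)cc1` share one core; compound 3 `CC(C)(C)OC(=O)N(Cc1ccco1)C(=O)c1ccc(CN2C(=O)c3ccccc3C2=O)cc1` and compound 4 `O=C(NCc1ccco1)c1ccc(CN2C(=O)c3ccccc3C2=O)cc1` share another. The cores differ by a group of 11 heavy atoms (8 carbon, 1 nitrogen, 2 oxygen; one five-membered non-aromatic ring with 1 hetero atom, one six-membered aromatic ring of carbon only) in place of a group of 10 heavy atoms (8 carbon, 1 nitrogen, 1 oxygen; one five-membered non-aromatic ring with 1 hetero atom, one six-membered aromatic ring of carbon only), on a saturated chain carbon bound to an aromatic carbon and the step from this core change is large: a 15-fold lower number from compound 1 to compound 3 (1.18 log units; beyond the scatter).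

The change from compound 3 to compound 4 is hydrogen in place of tert-butoxycarbonyl on an amide-type nitrogen. The same change has been made once already, between compound 1 and compound 2, where it reads (hydrogen in place of tert-butoxycarbonyl on an amide-type nitrogen). The two place descriptions agree word for word, so this is the same change and not merely the same kind. In a functional assay on RAW264.7 cells (Mus musculus) for inhibition (on this read-out lower numbers stand for stronger inhibition and higher numbers for weaker inhibition), compound 1 gives 51800 nM and compound 2 gives 49700 nM; the step is a 1.0-fold lower number from compound 1 to compound 2 (0.02 log units; within the scatter). In this assay compound 3 gives 3450 nM, the lowest of the three numbers, with the next nearest being compound 2 a wide step away.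

For compound 4 the expectation rests on that single earlier instance: removing the tert-butoxycarbonyl left the read-out flat on the first core, so the step from compound 3 to compound 4 is estimated at a 1.0-fold higher number from compound 3 to compound 4 (0.01 log units; within the scatter), which is taken to be within the scatter. The second core is only represented by one measured pair, so the transfer is uncertain. Compound 4 is expected to give about 3500 nM in this assay, with a plausible range from 1500 nM to 9000 nM.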

Compound 4, half-maximal inhibitory concentration: 56000 nM
Compound 4: the middle estimate sits 16-fold (1.20 log units) below what was measured, outside the stated range (above it).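

On the core of compound 3, hydrogen in place of tert-butoxycarbonyl on the amide-type nitrogen gives a 16-fold higher number from compound 3 to compound 4 (1.21 log units; beyond the scatter) in this assay. Within the data shown here, the same change therefore does not carry over unchanged from one core to the other, and its size cannot be read from one core alone: the same change on two cores in this assay, a 1.0-fold lower number (0.02 log units; within the scatter) from compound 1 to compound 2 and a 16-fold higher number (1.21 log units; beyond the scatter) from compound 3 to compound 4, 17-fold (1.23 log units) apart, beyond the scatter of two such steps This rests on only two pairs, so it sets no rule for any further core and gives no cause for the difference; in this assay, compound 2 gives 49700 nM and compound 4 gives 56000 nM, so the low number of compound 3 is seen only with the tert-butoxycarbonyl in place.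

The compounds shown leave open whether the low number of compound 3 is tied to tert-butoxycarbonyl itself or would persist with another group on that nitrogen, such as acetyl, methyl or benzyloxycarbonyl. They also leave open whether the dependence on the core persists when the furan ring of the furfuryl group gives way to a phenyl ring, as in a benzyl amide.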